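The source may report more compounds than this note shows. Statements on the series, on what has been measured and on what is new or still open speak of the compounds shown alone.

The measured compounds:

compound 1 `CNC(=O)c1cc(Oc2ccc3oc(Nc4ccccc4F)nc3c2)ccn1` – 10 10^-6 cm/s
compound 2 `CCc1ccccc1Nc1nc2cc(Oc3ccnc(C(=O)NC)c3)ccc2o1` – 10 10^-6 cm/s
compound 3 `CCc1ccc(Nc2nc3cc(Oc4ccnc(C(=O)NC)c4)ccc3o2)cc1` – 10 10^-6 cm/s

In an ADME assay on Caco-2 cells (Homo sapiens) for permeability, in the apical to basolateral direction (on this read-out lower numbers stand for lower permeability and higher numbers for higher permeability), compound 3 gives 10 10^-6 cm/s, and it stands level with compound 1 and compound 2 at the digits shown: the gap to compound 1 and the gap to compound 2 are both within the usual scatter. Compound 4 `CNC(=O)c1cc(Oc2ccc3oc(Nc4ccc(C(C)C)cc4)nc3c2)ccn1` differs from compound 3 in one place: methyl in place of hydrogen on a saturated chain carbon bound to an aromatic carbon and a saturated chain carbon. Three earlier steps bear on this change, since each alters only the group on the same aryl nitrogen. Replacing fluoro with ethyl gave no change at the digits printed from compound 1 to compound 2 (within the scatter); moving from 2-fluorophenyl to 4-ethylphenyl gave no change at the digits printed from compound 1 to compound 3 (within the scatter); and moving the ethyl from the 2-position to the 4-position gave no change at the digits printed from compound 2 to compound 3 (within the scatter). None of these left the scatter, and the change from compound 3 to compound 4 is smaller still in what it adds. Within the data shown here, the expectation is therefore no step in this assay beyond the scatter. Compound 4 is expected to give 10 10^-6 cm/s, with a range from 5 10^-6 cm/s to 20 10^-6 cm/s. This estimate amounts to a step of no change at the digits printed from compound 3 to compound 4 (within the scatter).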

Compound 4, apparent permeability: 10 10^-6 cm/s
For compound 4 middle estimate and measured number coincide at the digits printed; low and high end bracket the measured number.
By their numbers in this assay, from the lowest: compounds 1, 2, 3 and 4 (each within the scatter of the next).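

In this assay, the one added methyl that turns 4-ethylphenyl into 4-isopropylphenyl gave no change at the digits printed from compound 3 to compound 4 (within the scatter) and is the first change shown on a saturated chain carbon bound to an aromatic carbon and a saturated chain carbon, the earlier steps having altered the fluoro or ethyl group or its place on the aryl ring. Among these compounds, the 4-isopropylphenyl group also stands level with the two groups in the earlier compounds that carry a substituent at another place on the ring, with no change at the digits printed from compound 2 to compound 4 (within the scatter) on replacing 2-ethylphenyl and no change at the digits printed from compound 1 to compound 4 (within the scatter) on replacing 2-fluorophenyl, so all four aryl groups on this nitrogen now share one read-out. No measurement at hand speaks to why the read-out stays flat across these groups.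

The compounds shown leave open whether this read-out would hold with an amine or a carboxylic acid on the aryl ring, or with a longer chain such as n-butyl in place of isopropyl. Also open, on these data alone, is what happens if a saturated ring such as cyclohexyl replaces the aryl group on this nitrogen, or if hydrogen replaces the methyl on the amide nitrogen.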